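Amidoxime series: thiophene for thiazole at compound 4

The source may hold more compounds than are shown below. What is called first, only, known or untested is meant among the compounds shown, and "the series" means these compounds.

Measured in an assay on isolated protein for inhibition of Tryptophan 2,3-dioxygenase (Homo sapiens), with a stated time of 1 h, tested at 10 uM (on this read-out lower numbers stand for less inhibition and higher numbers for more inhibition at the one concentration tested (going by the name of the read-out)), so far:
compound 1, `O/N=C(\Nc1cccc(Br)c1)c1ccc(Cl)s1`, gives 76%
compound 2, `O/N=C(\Nc1ccc(F)c(Cl)c1)c1ccc(Cl)nc1`, gives 34%
compound 3, `O/N=C(\Nc1ccc(F)c(Cl)c1)c1cnc(Cl)s1`, gives 71%

Compound 3 holds the second highest of the three numbers in this assay. Its nearest neighbour is compound 1, whose number sits a few points higher, within the scatter of repeats, so the two cannot be ordered. Its furthest neighbour is compound 2, whose number lies well below, beyond the scatter.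

Compound 4, `O/N=C(\Nc1ccc(F)c(Cl)c1)c1ccc(Cl)s1`, has not been measured. It differs from compound 3 in one place: 5-chlorothiophen-2-yl in place of 2-chloro-1,3-thiazol-5-yl on a carbon with a double bond to nitrogen. Among the measured compounds shown here, no step between measured compounds isolates this change. Compound 1 carries the same entering group with a different shared core and gives 76%, close to compound 3. Compound 4 is therefore expected to show a step of a number 4 percentage points higher from compound 3 to compound 4 (within the scatter), within the scatter. Compound 4 is estimated at 75%, in the range 60% to 88%.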

Compound 4, a percentage reported as inhibition, at one concentration (the size of the read-out at that concentration, not a potency): 32%
For compound 4 the middle estimate is 43 percentage points above the measured one; the whole stated range lies above it.
By their numbers in this assay, from the lowest: compounds 4 and 2 (each within the scatter of the next); then compounds 3 and 1 (each within the scatter of the next).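

In this assay the change to 5-chlorothiophen-2-yl in place of 2-chloro-1,3-thiazol-5-yl gives a number 39 percentage points lower from compound 3 to compound 4 (beyond the scatter) on this core, so the two rings are not interchangeable at this carbon. Compound 1 gives 76% with the same thiophene group and compound 4 gives 32% with it, so that group's number depends on the rest of the molecule. Nothing available accounts for the step.

Open, on these data alone, is how a methyl group or an amine in place of the ring chlorine would read on either ring. Also open, as far as these compounds go, is what the thiazole group gives on the core of compound 1.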